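Ring contraction at the amide of compound 2

The source may report more compounds than this note shows. Statements on the series, on what has been measured and on what is new or still open speak of the compounds shown alone.

Compound 1 `CCOC(=O)c1cnc(-c2ccccc2)s1` gives > 100000 nM in an assay on HEK293 cells for inhibition of transient receptor potential cation channel subfamily M member 8 (Homo sapiens), read by FLIPR, with stated times of 5 min and 3 min (a higher number here means a weaker inhibitor, a lower number a stronger inhibitor), which is a limit of the assay rather than a number. Within the data shown here, compound 3 `CCOC(=O)c1sc(-c2ccccc2)nc1NC(=O)C(F)(F)F` gives 7700 nM in this assay; the only measured step, an at least 12-fold lower number from compound 1 to compound 3 (1.11 log units; beyond the scatter), follows the ((trifluoromethyl)carbonyl)amino group replacing hydrogen on an aromatic carbon. Compound 2 `O=C(c1sc(-c2cccc(F)c2)nc1O)N1CCCCCO1` gives 32 nM in this assay and holds the lowest of the two numbers, with compound 3 well above it. Compound 4 `O=C(c1sc(-c2cccc(F)c2)nc1O)N1CCOC1` has not yet been measured; it differs from compound 2 by a group of 5 heavy atoms (3 carbon, 1 nitrogen, 1 oxygen; one five-membered non-aromatic ring with 2 hetero atoms) in place of a group of 7 heavy atoms (5 carbon, 1 nitrogen, 1 oxygen; one seven-membered non-aromatic ring with 2 hetero atoms), on a carbonyl carbon. Among the measured compounds shown here, no measured step touches the amide ring of compound 2, and the step from compound 1 to compound 3 sits on a different core and at a different place, so it offers no guide to the size of this change. The expectation is therefore a step within the scatter: compound 4 is estimated at 50 nM in this assay, between 15 nM and 200 nM, meaning an expected 1.6-fold higher number from compound 2 to compound 4 (0.19 log units; within the scatter).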

Compound 4, half-maximal inhibitory concentration: 5500 nM
Estimate against measurement, compound 4: 110-fold (2.04 log units) below; measured number above the stated range.
By their numbers in this assay, from the lowest: compound 2; then compounds 4 and 3 (each within the scatter of the next). At a limit, above all of these: compound 1.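

Within this assay, the amide ring on the carbonyl carbon proves to be a position that matters: with the rest of the molecule unchanged, the five-membered ring in place of the seven-membered ring gives a 170-fold higher number from compound 2 to compound 4 (2.24 log units; beyond the scatter), a large step. The two rings match in their counted hydrogen-bond donors and acceptors and each holds 2 hetero atoms, so these counts do not separate them, while ring size and carbon count do. Among these compounds, this is also the first measured step on the shared core of compound 2 and compound 4, and it marks the amide ring as a place where potency can be lost.

The compounds shown leave open whether intermediate ring sizes or other amides, such as a piperidine or an open-chain dimethylamine on the same carbonyl carbon, would hold the number of compound 2. Among the compounds shown here, nothing measured so far speaks to why this step is so large.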